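A few compounds are considered here, and "the series" means these few. Any claim that something is new, unique, unknown or untested is made for them only; others in the source may bear on it.

In an ADME assay on HepG2 cells (Homo sapiens) for cytotoxicity, read by luminescence, with a stated time of 72 h (on this read-out higher numbers stand for an effect only at larger amounts of compound and lower numbers for an effect already at smaller amounts), compound 1 (`CCOC(=O)c1c(-c2cc(F)cc(OC)c2)[nH]c2cc(OC)ccc2c1=O`) gives > 21500 nM, which is a limit of the assay and not a number. Compound 2 (`CCOC(=O)c1c(-c2cccc(-c3ccccc3)c2)[nH]c2cc(OC)ccc2c1=O`) gives > 21500 nM, again a limit and not a number. Compound 2 therefore stands at the limit of > 21500 nM in this assay, at which 2 of the 2 values shown sit, and no measured number places it more exactly.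

Compound 3 (`CCCCOc1cccc(-c2[nH]c3cc(OC)ccc3c(=O)c2C(=O)OCC)c1`) has butoxy in place of phenyl on an aromatic carbon, meta to a large group: butoxy in place of phenyl on an aromatic carbon. Among the measured compounds shown here, no step between measured compounds is available to size this change. In this assay no step beyond the usual scatter is expected, a reading that rests only on compound 2 with its limit of > 21500 nM. The estimate for the change is a step that the limit leaves unreadable from compound 2 to compound 3. Compound 3 is expected at about 22000 nM, with an estimated range from 10000 nM to 40000 nM, and the assay may well report only a limit for it.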

Compound 3, half-maximal effective concentration: > 21500 nM
Compound 3 gave a limit, no number; the forecaster's own chance of this, stated with the estimate: 75%; the middle value does not contradict the limit.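

In this assay compound 2 and compound 3 each give only a limit and not a number, so no step can be read between them. The compounds shown leave open whether butoxy in place of phenyl changes the read-out at all beyond that limit.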